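Extending the Chain: A Longer Tail on the Shared Core

This account rests on a few compounds, and the source may have more. Where it says the series, first, only, none or still open, it means among the compounds named here.

Measured compounds:
- compound 1: `CCCCCCCCCCCCCCCCc1c(C)c(N(C)C)nc(C)c1O`, 52%
- compound 2: `CCCCCCCCCCc1c(C)c(N(C)C)nc(C)c1O`, 34%

In a functional assay on cells (Lymphocyte, Homo sapiens), read by trypan blue exclusion, with a stated time of 16 h, tested at 0.1 uM (a higher number here means a stronger effect of the compound at the concentration tested, a lower number a weaker effect), compound 2 gives 34%, the lower of the two numbers seen; compound 1 gives 52%. Among the measured compounds shown here, the one measured step bears directly on the question: a number 18 percentage points lower from compound 1 to compound 2 (beyond the scatter), so shortening the chain cost activity beyond the scatter. Compound 3, `CCCCCCCCCCCCCCCCCCCc1c(C)c(N(C)C)nc(C)c1O`, is not yet measured. It differs from compound 2 by nonyl in place of hydrogen on a saturated chain carbon, ten or more bonds along the chain from an aromatic carbon, which lengthens the chain in the direction that compound 1 shows to help. For the measured compounds named here, the only comparison available is that single step, and it does not show whether the gain continues beyond the length of compound 1 or levels off. On that basis compound 3 is expected to sit above compound 2, with a number 23 percentage points higher from compound 2 to compound 3 (beyond the scatter) as the estimated step. The estimate for compound 3 in this assay is 57%, within a range of 40% to 74%.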

Compound 3, a percentage reported as activity, at one concentration (the size of the read-out at that concentration, not a potency): 20%
Compound 3: the middle estimate sits 37 percentage points above what was measured, outside the stated range (below it).
By their numbers in this assay, from the lowest: compound 3; then compound 2; then compound 1.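

Lengthening the chain does not raise the number without limit at this position in this assay: nonyl in place of hydrogen on a saturated chain carbon, ten or more bonds along the chain from an aromatic carbon, gives a number 14 percentage points lower from compound 2 to compound 3 (beyond the scatter), and propyl in place of hydrogen at the same place gives a number 32 percentage points lower from compound 1 to compound 3 (beyond the scatter). Across these three compounds, the relation between chain length and the read-out is therefore not one-directional, with compound 1 standing above both the shorter chain of compound 2 and the longer chain of compound 3. No available evidence accounts for this reversal.

The compounds shown leave open how sharply the number rises and falls at chain lengths on either side of compound 1. They also leave open whether a chain ending in a carboxylic acid or an amine would follow the same course.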